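Urea series on SW-620 cells: removing one trifluoromethyl

A few compounds are considered here, and "the series" means these few. Any claim that something is new, unique, unknown or untested is made for them only; others in the source may bear on it.

Measured compounds:
compound 1 `O=C(Nc1cccc(-n2cc(-c3ccncc3)c(-c3cc(O)cc(Cl)c3)n2)c1)Nc1ccc(Cl)c(C(F)(F)F)c1`: -58%
compound 2 `COc1cc(Cl)cc(-c2nn(-c3cccc(NC(=O)Nc4cc(C(F)(F)F)cc(C(F)(F)F)c4)c3)cc2-c2ccncc2)c1`: -72%

In a functional assay on SW-620 cells (Homo sapiens) for inhibition, read by sulforhodamine B assay, with a stated time of 48 h, tested at 100 uM (a higher number here means a weaker effect of the compound at the concentration tested, a lower number a stronger effect), compound 2 gives -72%, the lowest of the two numbers. Compound 1 gives -58%, a number higher by more than the usual scatter; the two share the same core and differ at the urea end.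

Compound 3 `COc1cc(Cl)cc(-c2nn(-c3cccc(NC(=O)Nc4cccc(C(F)(F)F)c4)c3)cc2-c2ccncc2)c1` is not yet measured. It differs from compound 2 in one place: hydrogen in place of trifluoromethyl on an aromatic carbon. Among the measured compounds shown here, no measured pair shows this change, so its size is not known from the data. Removing a trifluoromethyl from the aryl urea is expected to move the number in this assay upward, toward a weaker effect, by a step of modest size that may not exceed the scatter. Compound 3 is expected at -55%, within a range from -80% to -25%. The expected step is a number 17 percentage points higher from compound 2 to compound 3 (beyond the scatter), with the direction more certain than the size.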

Compound 3, a percentage reported as activity, at one concentration (the size of the read-out at that concentration, not a potency): -11%
Compound 3: the middle estimate sits 44 percentage points below what was measured, outside the stated range (above it).
By their numbers in this assay, from the lowest: compound 2; then compound 1; then compound 3.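

In this assay, the second trifluoromethyl on the aryl urea is far from a minor feature: replacing it with hydrogen gives a number 61 percentage points higher from compound 2 to compound 3 (beyond the scatter), and most of the effect seen for compound 2 at the concentration tested is lost with this one change. Among the compounds shown here, compound 1 and compound 2 differ in more than one place, so this is the first step that can be assigned to a single position and a single change. No measurement shown explains why the step is this large.

From the compounds shown here alone, it remains open whether a small group such as methyl or nitrile at this place would keep the stronger effect of compound 2 or match compound 3. Going by these compounds, the result of removing the remaining trifluoromethyl from compound 3 is also open.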